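Extending the side chain of compound 1

The source may report more compounds than this note shows. Statements on the series, on what has been measured and on what is new or still open speak of the compounds shown alone.

Measured so far:
- Compound 1 (`CCN1C(=O)N[C@@](CN2Cc3ccc(OC)cc3C2=O)(c2cc3ncccc3o2)C1=O`) gives 378 ng.h/mL
- Compound 2 (`COc1ccc2c(c1)C(=O)N(C[C@]1(c3cc4ncccc4o3)C(=O)N(COC(=O)C(C)(C)C)C(=O)N1COC(=O)C(C)(C)C)C2`) gives 1920 ng.h/mL

Going by the values given here, both compounds were tested in an ADME assay on the whole organism for pharmacokinetics, with Rattus norvegicus as the target, read by LC-MS, at a dose of 10 mg/kg by the oral route (a higher number here means more compound in the circulation at the dose given, a lower number less compound in the circulation), and these are the only two numbers available. Compound 1 gives 378 ng.h/mL and so holds the lower of them. Compound 2 gives 1920 ng.h/mL and the gap between the two lies beyond the usual scatter of repeated measurements.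

The next compound to consider is compound 3 (`COCCOCCOCCN1C(=O)N[C@@](CN2Cc3ccc(OC)cc3C2=O)(c2cc3ncccc3o2)C1=O`). It keeps the core of compound 1 and changes in one place (2-(2-methoxyethoxy)ethoxy in place of hydrogen on a saturated chain carbon, two bonds along the chain from an amide-type nitrogen in a ring). The change is 2-(2-methoxyethoxy)ethoxy in place of hydrogen on a saturated chain carbon, two bonds along the chain from an amide-type nitrogen in a ring. The same difference can be read as ethyl giving way to 2-(2-(2-methoxyethoxy)ethoxy)ethyl.

Among the compounds with values here, no measured pair shows a change of this kind, so the expectation rests on compound 1 with its 378 ng.h/mL and remains uncertain. The expected step is a 1.3-fold lower number from compound 1 to compound 3 (0.10 log units; within the scatter) and it is expected to stay within the scatter, with no clear direction. For compound 3 the estimated value is 300 ng.h/mL (expected range 80 ng.h/mL to 1100 ng.h/mL).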

Compound 3, area under the concentration-time curve: 10.8 ng.h/mL
Compound 3: middle estimate off by 28-fold (1.44 log units), on the high side, outside the stated range (below it).
By their numbers in this assay, from the lowest: compound 3; then compound 1; then compound 2.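

In this assay, ethyl giving way to 2-(2-(2-methoxyethoxy)ethoxy)ethyl brings a 35-fold lower number from compound 1 to compound 3 (1.54 log units; beyond the scatter), a large step with the rest of the molecule unchanged. This shows that the position on a saturated chain carbon, two bonds along the chain from an amide-type nitrogen in a ring, is far from indifferent to what it carries: adding 2-(2-methoxyethoxy)ethoxy, with its 8 heavy atoms and no net charge, is enough to leave much less compound in the circulation at the dose given. Nothing among the data shown bears on what lies behind this drop.

One open question is how much of the step depends on the full length of this chain, which a shorter 2-methoxyethyl group would help to test, and whether the ether oxygens matter, which a plain hexyl chain would help to test. As far as these compounds go, it also remains open how the same position would respond to a chain ending in an amine or a carboxylic acid, since a single step cannot show whether other groups there would follow the same course.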